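The compounds below may be only part of what the source reports. "The series", "measured", "known", "first", "only" and "open" are said of these compounds alone.

Measured so far in a functional assay on the whole organism (strain Wistar) for inhibition, with Rattus norvegicus as the target, read by paw edema, with stated times of 30 min and 5 h, at a dose of 20 mg/kg by the oral route; a lower number here means less inhibition, a higher number more inhibition at the dose given (going by the name of the read-out):
- compound 1, `Cc1cc(O)c(C2=NN(c3ccc(S(N)(=O)=O)cc3)C(c3ccccc3Cl)C2)cc1Cl`, gives 71.4%
- compound 2, `Cc1cc(O)c(C2=NN(c3ccc(S(N)(=O)=O)cc3)C(c3ccc(Cl)cc3)C2)cc1Cl`, gives 71.4%
- compound 3, `COc1cc(C)c(Cl)cc1C1=NN(c2ccc(S(N)(=O)=O)cc2)C(c2ccccc2)C1`, gives 59.5%

Compound 3 sits lowest of these three numbers, and its gap to compound 1 and to compound 2 lies beyond the usual scatter in each case. Among the measured compounds shown here, the one step that has been measured between two compounds differing in a single place is no change at the digits printed from compound 1 to compound 2 (within the scatter): moving the chlorine from one position of the phenyl ring on the saturated ring carbon to another left the read-out unchanged. That step bears on what follows only loosely, since it changes a substituent already present rather than adding one.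

Compound 4, `COc1cc(C)c(Cl)cc1C1=NN(c2ccc(S(N)(=O)=O)cc2)C(c2ccc(N(C)C)cc2)C1`, differs from compound 3 by dimethylamino in place of hydrogen on an aromatic carbon. For the measured compounds named here, nothing among the measured compounds shows what a dimethylamino group does here, so the only guidance is that a change on this same phenyl ring, in no change at the digits printed from compound 1 to compound 2 (within the scatter), stayed within the scatter. A step of similar size is therefore expected, a number 2.5 percentage points higher from compound 3 to compound 4 (within the scatter), with no clear direction. Compound 4 is expected to give about 62%, within a range of 48% to 76%.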

Compound 4, a percentage reported as inhibition, in the whole organism at one dose (the size of the read-out at that dose, not a potency): 95.2%
For compound 4 the middle estimate is 33.2 percentage points below the measured one, outside the stated range (above it).
By their numbers in this assay, from the lowest: compound 3; then compounds 1 and 2 (each within the scatter of the next); then compound 4.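

In this assay, the change from phenyl to 4-(dimethylamino)phenyl gives a number 35.7 percentage points higher from compound 3 to compound 4 (beyond the scatter) at the dose tested. This shows that a group placed on an aromatic carbon of this ring, para to a large group, can shift the read-out by far more than the earlier chlorine change on the same ring, no change at the digits printed from compound 1 to compound 2 (within the scatter), suggested, so a change on this ring is not always a silent one. Nothing available here shows why dimethylamino has this effect, and no other measurement bears on the question.

The compounds shown leave open whether the rise depends on dimethylamino in particular, for none of them carries a plain amino group, a methoxy group or a longer chain at this place on the phenyl ring. As far as these compounds go, it also remains open whether dimethylamino would give a similar step on a compound with the hydroxyl group of compound 1 in place of the methoxy group of compound 3, or whether a chlorine already on this ring would alter the result.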